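The source may hold more compounds than are shown below. What is called first, only, known or untested is meant among the compounds shown, and "the series" means these compounds.

Compound 1 `O=C(CN1CCCCC1)Nc1ccc(-c2nc3cc(C(F)(F)F)ccc3[nH]2)cc1` was tested in an ADME assay on MT4 cells (Homo sapiens) for cytotoxicity, read by MTT assay, with a stated time of 96 h (a lower number here means that less compound is tolerated, a higher number that more compound is tolerated), where compound 1 gives 6000 nM. Its companion, compound 2 `Cn1c(-c2ccc(NC(=O)CN3CCCCC3)cc2)nc2cc(C(F)(F)F)ccc21`, differs from it only by methyl in place of hydrogen on an aromatic nitrogen, and in this assay compound 2 gives 9000 nM. The step is a 1.5-fold higher number from compound 1 to compound 2 (0.18 log units; within the scatter), so the two numbers are indistinguishable within the usual scatter; compound 1 simply holds the lower of the two figures.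

Compound 3 `O=C(CN1CCCCC1)Nc1ccc(-c2nc3ccccc3[nH]2)cc1` has not yet been measured. It differs from compound 1 in a single place: hydrogen in place of trifluoromethyl on an aromatic carbon. Among the measured compounds shown here, no measured step touches this position or this group; the only step known concerns the aromatic nitrogen and was itself within the scatter. There is therefore no basis for expecting a shift beyond the scatter in this assay , in either direction, and the expected step is no change at the digits printed from compound 1 to compound 3 (within the scatter). On that footing, compound 3 is estimated to give 6000 nM in this assay , with a likely range from 2500 nM to 15000 nM.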

Compound 3, half-maximal cytotoxic concentration: 31000 nM
For compound 3 the middle estimate is 5.2-fold (0.71 log units) below the measured one; measured number above the stated range.
By their numbers in this assay, from the lowest: compounds 1 and 2 (each within the scatter of the next); then compound 3.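

Replacing trifluoromethyl with hydrogen on this aromatic carbon gives a 5.2-fold higher number from compound 1 to compound 3 (0.71 log units; beyond the scatter) in this assay, so this is a place on the molecule where a single change moves the number clearly. The earlier step, methyl in place of hydrogen on the aromatic nitrogen, stayed within the scatter and showed no such sensitivity. Here the direction is also readable: with hydrogen on this carbon, more compound is tolerated than with trifluoromethyl, although nothing available explains why the number moves.

This single pair cannot show whether the shift is specific to trifluoromethyl or whether another group on the same carbon, such as a chlorine atom, a methoxy group or a nitrile, would give a number nearer that of compound 1 or that of compound 3. It also leaves open whether the same exchange would produce a step of similar size in compound 2, which carries methyl on the aromatic nitrogen.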